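The source may report more compounds than this note shows. Statements on the series, on what has been measured and on what is new or still open speak of the compounds shown alone.

Compound 1, `CC/N=C(/NC#N)NCCCCn1nc(-c2ccccc2)ccc1=O`, gives 58.8% in a functional assay on the whole organism with Rattus norvegicus as the target, at a dose of 100 mg/kg; a higher number here means more inhibition at the dose given (going by the name of the read-out), a lower number less inhibition.
Compound 2, `CC(C)(C)/N=C(\S)NCCCCn1nc(-c2ccccc2)ccc1=O`, gives 33.6% in the same test.

Among the compounds with values here, on these two numbers compound 1 stands highest; the only measured step, a number 25.2 percentage points lower from compound 1 to compound 2 (beyond the scatter), comes from exchanging a group on an amine nitrogen, a part of the molecule far from the ring. Compound 3, `CC/N=C(/NC#N)NCCCCn1nc(-c2ccccc2)cc(C)c1=O`, keeps that amine side chain of compound 1 unchanged and differs from it only at the shared core: methyl in place of hydrogen on an aromatic carbon. Within the data shown here, no measured step touches this aromatic carbon, so the step from compound 1 to compound 2 is the only comparison available and it does not bear on a change at the ring. With nothing pointing either way, the expected change is small, a number 3.8 percentage points lower from compound 1 to compound 3 (within the scatter), which is within the scatter. Compound 3 is therefore estimated at 55% in this assay, with a range from 35% to 75%.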

Compound 3, a percentage reported as inhibition, in the whole organism at one dose (the size of the read-out at that dose, not a potency): 42.5%
Beside the measured number, compound 3's estimate is 12.5 percentage points above it; the measured number falls inside the stated range.
By their numbers in this assay, from the lowest: compounds 2 and 3 (each within the scatter of the next); then compound 1.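

Within the data shown here, until this result, the only measured change lay on the amine side chain, so nothing showed whether the shared core mattered. Methyl in place of hydrogen on this aromatic carbon, with the side chain left as it is, gives a number 16.3 percentage points lower from compound 1 to compound 3 (beyond the scatter) in this assay, so a single added carbon here is enough to move the read-out. Nothing measured here gives a reason for this drop.

A single methyl cannot show whether the number falls further with a longer chain such as ethyl, or whether an amine or a chlorine atom on the same carbon would give a different result. Also open, as far as these compounds go, is whether methyl at this carbon would lower the number to a similar extent when the side chain is that of compound 2 .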